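A few compounds are considered here, and "the series" means these few. Any claim that something is new, unique, unknown or untested is made for them only; others in the source may bear on it.

Measured in an ADME assay for permeability, using PAMPA, with a stated time of 30 min, at pH 7.4; a higher number here means that the compound crosses the layer faster, a lower number that the compound crosses the layer more slowly:
compound 1 `c1ccc(Oc2ccc3c(NCCCNCc4ccco4)ccnc3c2)cc1` gives 317 10^-6 cm/s
compound 2 `Fc1ccc(-c2ccc3c(NCCCNCc4ccco4)ccnc3c2)cc1` gives 237 10^-6 cm/s
compound 3 `COc1ccc(Oc2ccc3c(NCCCNCc4ccco4)ccnc3c2)cc1` gives 317 10^-6 cm/s

Compound 3 stands level with compound 1 at the digits given, and all three numbers sit within the scatter of one another; the nearest to compound 3 is compound 1, the furthest compound 2, by a 1.3-fold higher number from compound 2 to compound 3 (0.13 log units; within the scatter).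

Compound 4 `c1ccc(CCc2ccc3c(NCCCNCc4ccco4)ccnc3c2)cc1` is the next member and is not yet measured. It differs from compound 3 as follows: phenethyl in place of 4-methoxyphenoxy on an aromatic carbon. The measured steps at that same aromatic carbon bear on it. a 1.3-fold lower number from compound 1 to compound 2 (0.13 log units; within the scatter) exchanged one group for another at this position and stayed within the scatter. no change at the digits printed from compound 1 to compound 3 (within the scatter) added a methoxy with no change. a 1.3-fold higher number from compound 2 to compound 3 (0.13 log units; within the scatter) likewise stayed within the scatter. Going by the values given here, every exchange made at this position so far has left the number where it was, so no step beyond the scatter is expected for a 1.1-fold lower number from compound 3 to compound 4 (0.04 log units; within the scatter), and compound 4 is expected to give about 290 10^-6 cm/s, in the range 190 10^-6 cm/s to 420 10^-6 cm/s.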

Compound 4, apparent permeability: 23 10^-6 cm/s
The estimate for compound 4 lay 13-fold (1.10 log units) above the measured number; measured number below the stated range.
By their numbers in this assay, from the lowest: compound 4; then compounds 2, 1 and 3 (each within the scatter of the next).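

In this assay, this aromatic carbon proves sensitive to the group it carries: phenethyl gives a 14-fold lower number from compound 3 to compound 4 (1.14 log units; beyond the scatter), a 14-fold lower number from compound 1 to compound 4 (1.14 log units; beyond the scatter) and a 10-fold lower number from compound 2 to compound 4 (1.01 log units; beyond the scatter), each beyond the scatter, while phenoxy, 4-fluorophenyl and 4-methoxyphenoxy remain within the scatter of one another. Since 4-methoxyphenoxy and phenethyl each hold one six-membered aromatic ring of carbon only, the presence of that ring does not by itself keep the number high. Nothing available explains the drop.

Open is whether the saturated chain of phenethyl or some other feature of the group goes with the low number, as phenethyl is the only group of its kind shown here. Benzyl, phenylpropyl or benzyloxy at the same carbon, or an amine on the phenethyl ring, would test how far this result extends.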